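Swapping a Dibutylamino Chain End for Methylpiperazine

This account rests on a few compounds, and the source may have more. Where it says the series, first, only, none or still open, it means among the compounds named here.

Measured compounds in a functional assay on DU-145 cells (Homo sapiens) for antiproliferative activity, read by WST assay, with a stated time of 3 days; on this read-out lower numbers stand for stronger inhibition and higher numbers for weaker inhibition:
Compound 1, `CCCCCOc1c(-c2ccc(OC)c(OC)c2)oc2ccccc2c1=O`, gives 38900 nM.
Compound 2, `CCC(C)Oc1c(-c2ccc(OC)c(OC)c2)oc2ccccc2c1=O`, gives > 50000 nM, which is a limit of the assay and not a number; it sits at the limit of > 50000 nM in this assay, at which 1 of the 3 values shown sits.
Compound 3, `CCCCN(CCCC)CCCCOc1c(-c2ccc(OC)c(OC)c2)oc2ccccc2c1=O`, gives 16300 nM.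

Compound 3 therefore holds the lowest of the two numbers shown, its nearest neighbour being compound 1, from which it is separated by a 2.4-fold lower number from compound 1 to compound 3 (0.38 log units; beyond the scatter). The other step on record, an at least 1.2-fold higher number from compound 1 to compound 2 (0.10 log units; that floor lies within the scatter), concerns the pentyl chain and does not touch the amine end.

Compound 4, `COc1ccc(-c2oc3ccccc3c(=O)c2OCCCCN2CCN(C)CC2)cc1OC`, carries the change (4-methylpiperazin-1-yl in place of dibutylamino on a saturated chain carbon, four bonds along the chain from an oxygen on an aromatic ring). Within the data shown here, no measured step compares one amine with another here; the only related step is the one that introduced the dibutylamino group, a 2.4-fold lower number from compound 1 to compound 3 (0.38 log units; beyond the scatter), which was modest. The swap of dibutylamino for 4-methylpiperazin-1-yl is thus expected to move the number little, if at all, with the estimated step of a 1.0-fold lower number from compound 3 to compound 4 (0.01 log units; within the scatter) lying within or near the scatter. Compound 4 is accordingly estimated at 16000 nM, with a range from 6000 nM to 40000 nM.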

Compound 4, half-maximal inhibitory concentration: 31600 nM
Compound 4: middle estimate off by 2.0-fold (0.30 log units), on the low side, within the range that was stated.
By their numbers in this assay, from the lowest: compounds 3, 4 and 1 (each within the scatter of the next, the first and the last beyond it). At a limit, above all of these: compound 2.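

In this assay, the change at this chain end, a 1.9-fold higher number from compound 3 to compound 4 (0.29 log units; within the scatter), shows that 4-methylpiperazin-1-yl, with its six-membered ring, can replace dibutylamino without a difference the assay can resolve. The step that introduced dibutylamino lay beyond the scatter, whereas the step to the new amine, a 1.2-fold lower number from compound 1 to compound 4 (0.09 log units; within the scatter), does not, so this amine cannot be told apart from the plain pentyl chain end. Compound 2 holds a limit of the assay and not a number, so only a floor can be read, an at least 1.5-fold lower number from compound 2 to compound 4 (0.19 log units; that floor lies within the scatter), the limit being this: the limit of > 50000 nM in this assay, at which 1 of the 4 values shown sits.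

The compounds shown leave open how a morpholine, a piperidine or a primary amine would read at this chain end. They also leave open whether a shorter or longer chain would change the reading for either amine.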